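Resorcinol isoxazole amides: a pyrazole in place of the isoxazole

The source may report more compounds than this note shows. Statements on the series, on what has been measured and on what is new or still open speak of the compounds shown alone.

The series rests on a shared core of a resorcinol bearing an isopropyl group joined to an isoxazole that carries an ethylcarbamoyl group. Compound 1 `CCNC(=O)c1noc(-c2cc(C(C)C)c(O)cc2O)c1-c1cc(CN)no1` carries an aminomethyl-substituted isoxazole on that core, but for compound 1 the entry in a functional assay on A2780 cells (Homo sapiens) for inhibition (on this read-out lower numbers stand for stronger inhibition and higher numbers for weaker inhibition), reads "not determined" (no result reported). Going by the values given here, compound 2 `C=CNCc1cc(-c2c(C(=O)NCC)noc2-c2cc(C(C)C)c(O)cc2O)on1` is the only member with a number: in this assay compound 2 gives 43 nM, so it stands alone on the read-out and no step between two measured compounds is available. Compound 3 `CCNC(=O)c1noc(-c2cc(C(C)C)c(O)cc2O)c1-c1ccn(C)n1` differs from compound 2 in one place: 1-methyl-1H-pyrazol-3-yl in place of 3-((vinylamino)methyl)-1,2-oxazol-5-yl on an aromatic carbon. Among the compounds with values here, with no measured step to lean on, the direction of the change is open; a step somewhat beyond the usual scatter, toward weaker inhibition, is what is expected. Compound 3 is therefore estimated to give 120 nM, within a range from 30 nM to 500 nM, which means an expected step of a 2.8-fold higher number from compound 2 to compound 3 (0.45 log units; beyond the scatter).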

Compound 3, half-maximal inhibitory concentration: 12 nM
For compound 3 the middle estimate is 10-fold (1.00 log units) above the measured one; measured number outside the range, below it.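

In this assay, the 1-methyl-1H-pyrazol-3-yl group in place of 3-((vinylamino)methyl)-1,2-oxazol-5-yl gives a 3.6-fold lower number from compound 2 to compound 3 (0.55 log units; beyond the scatter), so the group on this aromatic carbon, next to the ring atom that bears an ethylcarbamoyl group, does affect the read-out. The step also shows that the larger group, with its side chain and hydrogen-bond donor, is not required for a low number here, as the entering group has neither. Nothing measured accounts for the gain in inhibition.

This single step changes the ring and removes the side chain at once, so the contribution of each stays unresolved. Going by these compounds, whether a pyrazole carrying an aminomethyl group or a bare 1,2-oxazol-5-yl ring would separate the two remains open.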